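This account rests on a few compounds, and the source may have more. Where it says the series, first, only, none or still open, it means among the compounds named here.

Compound 1 `CCN(CC)CCNC(=O)c1ccc(C(CC)(CC)c2ccc(OCCC(O)(CC)CC)c(C)c2)n1CC` is the starting point of this comparison. In an assay on cells for agonist activity at vitamin D3 receptor (Homo sapiens), with a stated time of 96 h (on this read-out higher numbers stand for an effect only at larger amounts of compound and lower numbers for an effect already at smaller amounts), compound 1 gives 2.3 nM, the lowest number among the three measured compounds. Its nearest companion is compound 3 `CCn1c(C(=O)NC(C)C(=O)O)ccc1C(CC)(CC)c1ccc(OCCC(O)(CC)CC)c(C)c1`, which in this assay gives 66 nM, and the furthest is compound 2 `CCOc1ccc(NC(=O)c2ccc(C(CC)(CC)c3ccc(OCCC(O)(CC)CC)c(C)c3)n2CC)cc1`, which in this assay gives 1630 nM. Both of these differ from compound 1 only in what sits on the amide-type nitrogen, and both steps were large: a 710-fold higher number from compound 1 to compound 2 (2.85 log units; beyond the scatter) and a 29-fold higher number from compound 1 to compound 3 (1.46 log units; beyond the scatter). Between them, a 25-fold lower number from compound 2 to compound 3 (1.39 log units; beyond the scatter).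

Compound 4 `CCn1c(C(=O)N(C)CCO)ccc1C(CC)(CC)c1ccc(OCCC(O)(CC)CC)c(C)c1` has not yet been measured in this assay. It differs from compound 1 by a single change at the carbonyl carbon: (2-hydroxyethyl)(methyl)amino in place of (2-(diethylamino)ethyl)amino on a carbonyl carbon. The two measured steps that bear on this one both replaced the 2-(diethylamino)ethyl group on the amide-type nitrogen and both raised the number strongly, so a step upward, well beyond the scatter, is expected here as well, though its size cannot be fixed from two examples.

Compound 4 is therefore expected to give 60 nM in this assay, within a range of 10 nM to 400 nM, which corresponds to an expected step of a 26-fold higher number from compound 1 to compound 4 (1.42 log units; beyond the scatter).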

Compound 4, half-maximal effective concentration: 52.7 nM
Estimate against measurement, compound 4: 1.1-fold (0.06 log units) above; the range from low to high includes it.
By their numbers in this assay, from the lowest: compound 1; then compounds 4 and 3 (each within the scatter of the next); then compound 2.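

The result shows that the high sensitivity of this position does not depend on bringing in a (4-ethoxyphenyl)amino or (1-carboxyethyl)amino group: in this assay, the smaller (2-hydroxyethyl)(methyl)amino group on the carbonyl carbon also gives a 23-fold higher number from compound 1 to compound 4 (1.36 log units; beyond the scatter). Two different replacements now read alike, with a 1.3-fold lower number from compound 3 to compound 4 (0.10 log units; within the scatter), whereas the (4-ethoxyphenyl)amino group stays well apart, with a 31-fold lower number from compound 2 to compound 4 (1.49 log units; beyond the scatter). Among these four compounds, all three replacements of the (2-(diethylamino)ethyl)amino group raise the number beyond the scatter, and none goes against this pattern, though the size of the rise depends on the group that enters.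

Nothing available explains these differences. The compounds shown also leave open whether the loss in compound 4 follows from removing the diethylamino end or from the methyl group on the amide nitrogen, and whether a 2-(dimethylamino)ethyl or 3-(diethylamino)propyl chain on that nitrogen would keep the low number of compound 1.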